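Solubility Estimate for a Third Amide from Two Measured Values

The source may report more compounds than this note shows. Statements on the series, on what has been measured and on what is new or still open speak of the compounds shown alone.

Compound 1 `O=C(CCl)Nc1cccc(-c2nc3ccccc3s2)c1`: 1000 nM
Compound 2 `O=C(Nc1cccc(-c2nc3ccccc3s2)c1)c1ccnc(Cl)c1`: 740 nM

In a physicochemical assay for solubility, in phosphate buffer, measured as kinetic solubility, with a stated time of 18 h, at pH 7.4 (on this read-out lower numbers stand for lower solubility and higher numbers for higher solubility), compound 1 gives 1000 nM, the larger of the two numbers recorded, although the gap to compound 2 is within the scatter. Among the measured compounds shown here, compound 2 gives 740 nM, and the single measured step is a 1.4-fold lower number from compound 1 to compound 2 (0.13 log units; within the scatter). Compound 3 `O=C(Nc1cccc(-c2nc3ccccc3s2)c1)c1ccncc1Cl` has not been measured in this assay. Compared with compound 1, the change is 3-chloropyridin-4-yl in place of chloromethyl on a carbonyl carbon. For the measured compounds named here, the only step that bears on it is a 1.4-fold lower number from compound 1 to compound 2 (0.13 log units; within the scatter), where a 2-chloropyridin-4-yl group likewise replaced chloromethyl on the same carbonyl carbon and the number stayed within the scatter. A ring of the same kind enters here, now named 3-chloropyridin-4-yl, so no step beyond the scatter is expected, a 1.3-fold lower number from compound 1 to compound 3 (0.10 log units; within the scatter). Compound 3 is therefore estimated at 800 nM, with a range from 350 nM to 1800 nM.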

Compound 3, solubility: 320 nM
Compound 3: middle estimate off by 2.5-fold (0.40 log units), on the high side; measured number outside the range, below it.
By their numbers in this assay, from the lowest: compound 3; then compounds 2 and 1 (each within the scatter of the next).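

Among the compounds shown here, the carbonyl carbon proved sensitive to which ring enters, as this change produced the first step beyond the scatter in this assay (a 3.1-fold lower number from compound 1 to compound 3 (0.49 log units; beyond the scatter)), whereas 2-chloropyridin-4-yl had left the number within the scatter of the chloromethyl compound. The two chloropyridinyl groups are therefore not interchangeable at this place, since 3-chloropyridin-4-yl in place of 2-chloropyridin-4-yl also gives a step beyond the scatter (a 2.3-fold lower number from compound 2 to compound 3 (0.36 log units; beyond the scatter)). No measurement shown here accounts for the difference between these two groups.

From the compounds shown here alone, with only these three compounds, it remains open how a plain pyridin-4-yl group without chlorine or a phenyl group would read on the same carbonyl carbon. Going by these compounds, it is equally open whether a longer chain ending in an amine would stay near chloromethyl or fall nearer the 3-chloropyridin-4-yl group.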